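Trading a Methoxy for Fluoro at the Assay Limit

The source may report more compounds than this note shows. Statements on the series, on what has been measured and on what is new or still open speak of the compounds shown alone.

compound 1 `COc1cc(-c2cccc3nc(-c4ccc(Cl)cc4)oc23)cc(OC)c1OC` gives 1600 nM as measured
compound 2 `COc1cc(-c2cccc3nc(-c4ccc5cc[nH]c5c4)oc23)cc(OC)c1OC` gives 300 nM as measured
compound 3 `COc1ccc(-c2nc3c(-c4cc(OC)c(OC)c(OC)c4)cccc3o2)cc1OC` gives > 25000 nM as measured

All three values come from a functional assay on U-251 cells (Homo sapiens) for antiproliferative activity, read by MTT assay, with a stated time of 48 h (on this read-out higher numbers stand for weaker inhibition and lower numbers for stronger inhibition), on the same read-out. Compound 3 stands at > 25000 nM as a limit of the assay, not as a number. The data thus show the limit of > 25000 nM in this assay, at which 1 of the 3 values shown sits, and offer no exact starting point for the next step.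

Compound 4 `COc1ccc(-c2nc3c(-c4cc(OC)c(OC)c(OC)c4)cccc3o2)cc1F` differs from compound 3 in one place: fluoro in place of methoxy on an aromatic carbon on a ring where the fluoro sits ortho to a methoxy group and meta to a large group. In short, 3,4-dimethoxyphenyl becomes 3-fluoro-4-methoxyphenyl.

Within the data shown here, only one measured step touches this aryl group, and it bears only loosely: a 5.3-fold lower number from compound 1 to compound 2 (0.73 log units; beyond the scatter) shows that changing the group can move the number by a modest amount. Compound 1, with 4-chlorophenyl and no methoxy on that ring, gives 1600 nM as a true number. A lower number is therefore expected, although compound 4 may well stay at the limit. Expected here is an at least 2.7-fold lower number from compound 3 to compound 4 (0.44 log units; beyond the scatter) as a rough estimate. Compound 4 is estimated at 9000 nM within an expected range of 2000 nM to 25000 nM on this read-out.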

Compound 4, half-maximal inhibitory concentration: 19400 nM
For compound 4 the middle estimate is 2.2-fold (0.33 log units) below the measured one; low and high end bracket the measured number.
By their numbers in this assay, from the lowest: compound 2; then compound 1; then compound 4. At a limit, above all of these: compound 3.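

In this assay compound 4 gives 19400 nM, a true number, so this position, ortho to a methoxy group and meta to a large group, now has a measured value with the 3-fluoro-4-methoxyphenyl group, which compound 3 could not provide. The comparison reads an at least 1.2-fold lower number from compound 3 to compound 4 (0.11 log units; that floor lies within the scatter), so the data show only a minimum for the change, and that minimum is too small to establish a real difference from a single replacement of methoxy by fluoro. Compound 3 remains a limit and not a number, so the true size of the step cannot be read, and it could be much larger than this minimum: the limit of > 25000 nM in this assay, at which 1 of the 4 values shown sits.

The compounds shown carry only methoxy or fluoro at this position, so it remains open whether the number depends on the particular group placed there or merely on the methoxy being gone. An amine, a hydroxyl group or a plain hydrogen at the same place would help separate these two readings, provided the resulting values fall within the measurable range of the assay.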